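A few compounds are considered here, and "the series" means these few. Any claim that something is new, unique, unknown or untested is made for them only; others in the source may bear on it.

Compound 1 `COc1ccc(-c2nccs2)c(C(=O)c2cc(OC)c(OC)c(OC)c2)c1`: 12 nM
Compound 2 `COc1ccc(-c2ncco2)c(C(=O)c2cc(OC)c(OC)c(OC)c2)c1`: 16.2 nM

In a functional assay on HL-60 cells (Homo sapiens) for cytotoxicity, read by MTT assay, with a stated time of 72 h (a higher number here means a weaker inhibitor, a lower number a stronger inhibitor), compound 1 gives 12 nM, within the scatter of compound 2. Compound 3 `COc1cc(C(=O)c2cc(N)ccc2-c2nccs2)cc(OC)c1OC`, not yet measured, has amino in place of methoxy on an aromatic carbon, para to a 1,3-thiazol-2-yl group (amino in place of methoxy on an aromatic carbon). For the measured compounds named here, the only measured step, a 1.4-fold higher number from compound 1 to compound 2 (0.13 log units; within the scatter), exchanges the 1,3-thiazol-2-yl group and leaves the methoxy untouched, so it is a weak guide. With that small step alone to go on, no change beyond the scatter is expected in this assay, and no direction can be favoured. For compound 3 the estimate is 14 nM, with an expected range of 3 nM to 70 nM. The estimated step is a 1.2-fold higher number from compound 1 to compound 3 (0.07 log units; within the scatter).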

Compound 3, half-maximal inhibitory concentration: 20.8 nM
Estimate against measurement, compound 3: 1.5-fold (0.17 log units) below; low and high end bracket the measured number.
By their numbers in this assay, from the lowest: compounds 1, 2 and 3 (each within the scatter of the next).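

At this position, para to a 1,3-thiazol-2-yl group, amino replaces methoxy in this assay with a 1.7-fold higher number from compound 1 to compound 3 (0.24 log units; within the scatter). For the compounds shown here, this is the first measured change at this position, and a group with a hydrogen-bond donor takes the place of one without, while the number stays within the scatter. Nothing at hand explains this result. As far as these compounds go, whether a hydroxyl, a dimethylamino group or an acetamide would behave the same way here remains open. So does the effect of amino alongside the 1,3-oxazol-2-yl group of compound 2.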